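The source may report more compounds than this note shows. Statements on the series, on what has been measured and on what is new or still open speak of the compounds shown alone.

Measured compounds:
- compound 1 `N#CC1=C(N)Oc2c(N)cc3nc4ccccc4nc3c2C12C(=O)N(Cc1cnnn1-c1ccc(F)cc1)c1ccccc12`: > 50000 nM
- compound 2 `CC(=O)Nc1ccc(-n2nncc2CN2C(=O)C3(C(C#N)=C(N)Oc4c(N)cc5nc6ccccc6nc5c43)c3ccccc32)cc1`: > 50000 nM
- compound 3 `Cc1cc(C)cc(-n2nncc2CN2C(=O)C3(C(C#N)=C(N)Oc4c(N)cc5nc6ccccc6nc5c43)c3ccccc32)c1`: > 50000 nM

The three compounds share one core and differ only in the aryl group on the triazole nitrogen. In an ADME assay on L02 cells (Homo sapiens) for antiproliferative activity, read by MTT assay, with a stated time of 48 h (a higher number here means a weaker inhibitor, a lower number a stronger inhibitor), compound 3 gives > 50000 nM, which is a limit of the assay and not a number. Compound 1 likewise gives a limit, > 50000 nM. Compound 2 also gives a limit, > 50000 nM. All three therefore sit at the limit of > 50000 nM in this assay, at which 3 of the 3 values shown sit, so no size can be read for a step that the two limits leave unreadable from compound 1 to compound 3, for a step that the two limits leave unreadable from compound 2 to compound 3 or for a step that the two limits leave unreadable from compound 1 to compound 2.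

Compound 4 `Cc1ccc(-n2nncc2CN2C(=O)C3(C(C#N)=C(N)Oc4c(N)cc5nc6ccccc6nc5c43)c3ccccc32)cc1Cl` carries the change (3-chloro-4-methylphenyl in place of 3,5-dimethylphenyl on an aromatic nitrogen). Every measured step around this position runs from one limit to another, so the change of aryl group has so far not moved any compound into the measurable range. With nothing pointing in another direction, compound 4 is expected to give 60000 nM, with a range from 30000 nM to 200000 nM. The expected step in this assay, a step that the limit leaves unreadable from compound 3 to compound 4, is estimated as none beyond the scatter, most likely again a limit.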

Compound 4, half-maximal inhibitory concentration: > 50000 nM
Compound 4: only a limit was reported; the forecaster's own chance of this, stated with the estimate: 85%; the middle value is on the limit's open side.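

In this assay compound 4 gives > 50000 nM, which is a limit of the assay and not a number. No step linking it to compound 1, compound 2 or compound 3 can therefore be read: the limit of > 50000 nM in this assay, at which 4 of the 4 values shown sit.

The compounds shown leave open how far each lies past this limit and whether any aryl group on the aromatic nitrogen would give a measurable value.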